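A Longer Unsaturated Chain on a Flat Series

The compounds below may be only part of what the source reports. "The series", "measured", "known", "first", "only" and "open" are said of these compounds alone.

Compound 1 `CCCCCCn1cnc2c(Nc3cccc(Cl)c3)nc(N[C@H]3CC[C@H](N)CC3)nc21`: 5100 nM
Compound 2 `CCCCn1cnc2c(Nc3cccc(Cl)c3)nc(N[C@H]3CC[C@H](N)CC3)nc21`: 5100 nM

In a functional assay on BT-474 cells (Homo sapiens) for inhibition, read by fluorescence, with a stated time of 72 h (a lower number here means a stronger inhibitor of growth, a higher number a weaker inhibitor of growth), compound 1 gives 5100 nM and compound 2 gives 5100 nM, so the two stand level at the digits shown. The next structure is compound 3 `CC(C)=CCC/C(C)=C/Cn1cnc2c(Nc3cccc(Cl)c3)nc(N[C@H]3CC[C@H](N)CC3)nc21`, which keeps the shared core of compound 2 and alters only the chain. The change is 2,6-dimethylhepta-1,5-dien-1-yl in place of propyl on a saturated chain carbon bound to an aromatic nitrogen.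

Among the measured compounds shown here, only one measured step bears on this, and it concerns the same chain: no change at the digits printed from compound 1 to compound 2 (within the scatter). For the measured compounds named here, that gives a single small step as evidence, and no measured compound carries double bonds in this chain, so the forecast is uncertain. Resting on that step, no change beyond the scatter is expected in this assay, in either direction, and the range is kept wide. The expected size is a 1.1-fold lower number from compound 2 to compound 3 (0.05 log units; within the scatter). For compound 3 the estimate is 4500 nM, with an expected range from 1800 nM to 11000 nM.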

Compound 3, concentration for 50% growth inhibition: 4300 nM
Compound 3: the middle estimate sits 1.0-fold (0.02 log units) above what was measured; measured number inside the range.
By their numbers in this assay, from the lowest: compounds 3, 1 and 2 (each within the scatter of the next).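

In this assay, the 2,6-dimethylhepta-1,5-dien-1-yl group in place of propyl on a saturated chain carbon bound to an aromatic nitrogen gives a 1.2-fold lower number from compound 2 to compound 3 (0.07 log units; within the scatter), and the same group in place of pentyl gives a 1.2-fold lower number from compound 1 to compound 3 (0.07 log units; within the scatter). The earlier pair showed only that trimming a saturated chain left the number unmoved, whereas these steps extend that flat picture to a branched chain with two double bonds outside aromatic rings, so across these three compounds neither the size nor the shape of the chain has shifted growth inhibition beyond the scatter. No measurement shown here explains this flat result.

Compound 3 brings in chain size, branching and double bonds all at once, so these compounds cannot show what each would do alone, although none of them changed the number here. From the compounds shown here alone, it also remains open whether this place responds to anything other than a plain hydrocarbon chain, such as a chain ending in an amine or a carboxylic acid, or a benzyl group.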